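Moving the chlorine on the aryl of compound 3

A few compounds are considered here, and "the series" means these few. Any claim that something is new, unique, unknown or untested is made for them only; others in the source may bear on it.

Compounds measured so far:
Compound 1, `Cc1cccc(-c2nc(CNc3ccc(C(=O)NO)cc3)n(-c3ccccc3)n2)c1`: 281 nM
Compound 2, `O=C(NO)c1ccc(NCc2nc(-c3cccs3)nn2-c2ccc(O)cc2)cc1`: 33.5 nM
Compound 3, `O=C(NO)c1ccc(NCc2nc(-c3ccccc3)nn2-c2ccccc2Cl)cc1`: 669 nM

The three compounds share a hydroxamic acid core and differ in the two aryl groups on the five-membered ring. In an assay on Sf9 cells for inhibition of protein deacetylase HDAC6 (Homo sapiens), read by fluorescence, with a stated time of 40 min (a higher number here means a weaker inhibitor, a lower number a stronger inhibitor), compound 2 gives 33.5 nM, compound 1 gives 281 nM and compound 3 gives 669 nM. Compound 3 thus stands at the highest number of the three: its gap to compound 1 lies beyond the scatter, and its gap to compound 2 is far beyond it, so compound 3 is the weakest inhibitor of the measured set.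

Compound 4, `O=C(NO)c1ccc(NCc2nc(-c3ccccc3)nn2-c2cccc(Cl)c2)cc1`, has not yet been measured. It differs from compound 3 in one place: 3-chlorophenyl in place of 2-chlorophenyl on an aromatic nitrogen. Among the measured compounds shown here, no measured pair shows this change, so nothing in the data tells its size or direction. The writer expects a step of small size from compound 3 to compound 4, of the order of a 1.5-fold lower number from compound 3 to compound 4 (0.17 log units; within the scatter), which would not clearly leave the scatter. The estimate for compound 4 in this assay is therefore 450 nM, with a plausible range from 150 nM to 1400 nM.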

Compound 4, half-maximal inhibitory concentration: 678 nM
Beside the measured number, compound 4's estimate is 1.5-fold (0.18 log units) below it, within the range that was stated.
By their numbers in this assay, from the lowest: compound 2; then compound 1; then compounds 3 and 4 (each within the scatter of the next).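

In this assay, putting 3-chlorophenyl in place of 2-chlorophenyl on the aromatic nitrogen gives a 1.0-fold higher number from compound 3 to compound 4 (0.01 log units; within the scatter), so this read-out does not separate the two compounds. Among the compounds shown here, this is the first pair in the set that differs in one place only, and it shows that, with everything else held the same, these two placements of the chlorine on the aryl cannot be told apart here. The data offer no independent measurement that could explain why the two compounds stand so close.

It remains open whether the chlorine itself matters at this place, since no pair shown sets a chlorophenyl against a plain phenyl with all else the same, and whether a methoxy group, an amine or a carboxylic acid on this aryl would shift the number. Compound 2, at 33.5 nM, differs from compound 3 and compound 4 in more than one place, so its much lower number cannot be assigned to either of its aryl groups.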